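Swapping the 2-aminophenyl group of compound 2 for hydroxy

The compounds below may be only part of what the source reports. "The series", "measured", "known", "first", "only" and "open" are said of these compounds alone.

Compound 1 `CC(C)Oc1ccc(C(C)(C)O)cc1-c1cn(C)c(=O)c2[nH]c(C(=O)NCCCCCCC(=O)NO)cc12`: 160 nM
Compound 2 `CC(C)Oc1ccc(C(C)(C)O)cc1-c1cn(C)c(=O)c2[nH]c(C(=O)NCc3ccc(C(=O)Nc4ccccc4N)cc3)cc12`: 40 nM
Compound 3 `COc1ccc(C(C)(C)O)cc1-c1cn(C)c(=O)c2[nH]c(C(=O)NCc3ccc(C(=O)Nc4ccccc4N)cc3)cc12`: 420 nM

In a functional assay on MV4-11 cells (Homo sapiens) for antiproliferative activity, read by CCK-8 assay, with a stated time of 72 h (on this read-out lower numbers stand for stronger inhibition and higher numbers for weaker inhibition), compound 2 has the lowest of the three numbers. Compound 4 `CC(C)Oc1ccc(C(C)(C)O)cc1-c1cn(C)c(=O)c2[nH]c(C(=O)NCc3ccc(C(=O)NO)cc3)cc12` differs from it in one place: hydroxy in place of 2-aminophenyl on an amide-type nitrogen. Among the compounds with values here, no measured step covers this swap. The only one, an 11-fold higher number from compound 2 to compound 3 (1.02 log units; beyond the scatter), concerns a group on an oxygen on an aromatic ring, and shows only that a small edit can matter in this series. Closer evidence comes from compound 1, which also carries hydroxycarbamoyl, on a different linker, and gives 160 nM. A moderate move towards a higher number in this assay is therefore expected. The estimated change is a 2.5-fold higher number from compound 2 to compound 4 (0.40 log units; beyond the scatter). Compound 4 is estimated at 100 nM, within a range of 30 nM to 350 nM.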

Compound 4, half-maximal inhibitory concentration: 350 nM
Compound 4: middle estimate off by 3.5-fold (0.54 log units), on the low side, and the stated range covers the measured number.
By their numbers in this assay, from the lowest: compound 2; then compound 1; then compounds 4 and 3 (each within the scatter of the next).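

On the amide-type nitrogen, the choice of group clearly matters in this assay: hydroxy in place of 2-aminophenyl gives an 8.8-fold higher number from compound 2 to compound 4 (0.94 log units; beyond the scatter) in this series. With hydroxycarbamoyl kept, the linker also counts, as 4-(hydroxycarbamoyl)phenyl in place of 5-(hydroxycarbamoyl)pentyl gives a 2.2-fold higher number from compound 1 to compound 4 (0.34 log units; beyond the scatter) on this read-out. No supporting measurement explains either step.

The compounds shown leave open how much of the difference rests on the amino group of 2-aminophenyl, which a plain phenyl or a 2-hydroxyphenyl group on that nitrogen would test. They also leave open how a longer saturated chain would compare.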